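A Benzyl-to-Aryl Swap on the Ring Nitrogen

This account rests on a few compounds, and the source may have more. Where it says the series, first, only, none or still open, it means among the compounds named here.

Measured in an ADME assay on CCRF-CEM cells (Homo sapiens) for cytotoxicity, read by MTT assay, with a stated time of 5 days; a higher number here means that more compound is tolerated, a lower number that less compound is tolerated:
compound 1 `COc1cc(Cc2cnc(/N=C3\C(=O)N(CN4CCN(Cc5ccccc5)CC4)c4ccc(Cl)cc43)nc2N)cc(OC)c1OC`: 94.7 ug/mL
compound 2 `CCn1cc(C(=O)O)c(=O)c2cc(F)c(N3CCN(CN4C(=O)/C(=N\c5ncc(Cc6cc(OC)c(OC)c(OC)c6)c(N)n5)c5cc(Cl)ccc54)C(C)C3)c(F)c21`: 18.7 ug/mL

Of these two, compound 1 stands highest at 94.7 ug/mL, and the gap down to compound 2 at 18.7 ug/mL lies beyond the scatter. Compound 3 `COc1cc(Cc2cnc(/N=C3\C(=O)N(CN4CCN(c5ccc(F)cc5)CC4)c4ccc(Cl)cc43)nc2N)cc(OC)c1OC` keeps the core of compound 1 but carries 4-fluorophenyl in place of benzyl on an amine nitrogen in a ring. Going by the values given here, no measured pair shows this change, so only a small downward move is expected in this assay, the estimated step being a 1.7-fold lower number from compound 1 to compound 3 (0.24 log units; within the scatter). For compound 3 the expected value is 55 ug/mL, with an estimated range of 18 ug/mL to 120 ug/mL.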

Compound 3, half-maximal cytotoxic concentration: 71 ug/mL
Beside the measured number, compound 3's estimate is 1.3-fold (0.11 log units) below it; the measured number falls inside the stated range.
By their numbers in this assay, from the lowest: compound 2; then compounds 3 and 1 (each within the scatter of the next).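

Going by these compounds alone, on the amine nitrogen in a ring, this is the first change that can be read as a single step in this assay: a 1.3-fold lower number from compound 1 to compound 3 (0.13 log units; within the scatter). Compound 1 and compound 3 carry groups of equal heavy-atom count, so at this position the step from benzyl to 4-fluorophenyl stays within the scatter. Nothing available explains this result.

What the compounds shown leave open is whether plain phenyl would behave like 4-fluorophenyl here. From the compounds shown here alone, it is also open whether an amine or a carboxylic acid on this ring nitrogen's aryl group would stay within the scatter of compound 1.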